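A Single Fluoro Added to Compound 2

This account rests on a few compounds, and the source may have more. Where it says the series, first, only, none or still open, it means among the compounds named here.

Of the compounds shown here, two have so far been measured in a functional assay on MDA-MB-231 cells (Homo sapiens) for antiproliferative activity, read by MTT assay, with a stated time of 72 h; on this read-out higher numbers stand for weaker inhibition and lower numbers for stronger inhibition. Compound 1 `CC(=O)O[C@H]1CC[C@]2(C)[C@H](CC[C@@](C)(O)[C@H]2CC[C@@H]2C(C)=CC[C@H]3[C@H](CC[C@]3(C)O)C2(C)C)OC1(C)C` is the reference point; in this assay compound 1 gives 38000 nM. Compound 2 `CC1=CC[C@H]2[C@H](CC[C@]2(C)O)C(C)(C)[C@@H]1CC[C@H]1[C@]2(C)CC[C@H](OC(=O)c3ccc(C(F)(F)F)cc3)C(C)(C)O[C@H]2CC[C@@]1(C)O` carries 4-(trifluoromethyl)phenyl in place of methyl on a carbonyl carbon, and in this assay compound 2 gives 19500 nM. That step, a 1.9-fold lower number from compound 1 to compound 2 (0.29 log units; within the scatter), stays inside the scatter, so compound 2 holds the lowest of the two numbers without standing apart from compound 1.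

Compound 3 `CC1=CC[C@H]2[C@H](CC[C@]2(C)O)C(C)(C)[C@@H]1CC[C@H]1[C@]2(C)CC[C@H](OC(=O)c3ccc(C(F)(F)F)c(F)c3)C(C)(C)O[C@H]2CC[C@@]1(C)O` differs from compound 2 in one place: fluoro in place of hydrogen on an aromatic carbon. Among the measured compounds shown here, no measured step bears on a change of this kind; the only step known, a 1.9-fold lower number from compound 1 to compound 2 (0.29 log units; within the scatter), concerned a much larger exchange of groups and still moved nothing beyond the scatter. With no measurement pointing in either direction, the step from compound 2 to compound 3 is expected to lie within the scatter, namely a 1.1-fold lower number from compound 2 to compound 3 (0.06 log units; within the scatter). Compound 3 is therefore expected to give about 17000 nM in this assay, with a range from 7000 nM to 45000 nM.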

Compound 3, half-maximal inhibitory concentration: 22200 nM
For compound 3 the middle estimate is 1.3-fold (0.12 log units) below the measured one, and the stated range covers the measured number.
By their numbers in this assay, from the lowest: compounds 2, 3 and 1 (each within the scatter of the next).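

On the 4-(trifluoromethyl)phenyl group, fluoro on the aromatic carbon ortho to the trifluoromethyl group and meta to a large group gives a 1.1-fold higher number from compound 2 to compound 3 (0.06 log units; within the scatter) in this assay, so at this position the added atom leaves a number that cannot be told apart from that of compound 2. The larger exchange to 3-fluoro-4-(trifluoromethyl)phenyl in place of methyl on the carbonyl carbon gives a 1.7-fold lower number from compound 1 to compound 3 (0.23 log units; within the scatter), which means that adding this fluoro to the aromatic group still does not separate the result from compound 1 beyond the scatter. No measurement at hand explains these results or says what the fluoro does in the cells.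

The compounds shown leave open whether any other group on this aromatic carbon, such as a methoxy group, an amine or a nitrile, would give a step beyond the scatter. From the compounds shown here alone, it also remains open whether a carboxylic acid in place of the trifluoromethyl group, or a longer chain in place of the aromatic group on the carbonyl carbon, would separate from compound 1 in this assay.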